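The compounds below may be only part of what the source reports. "The series", "measured", "known", "first", "only" and "open" are said of these compounds alone.

In a physicochemical assay for solubility, in phosphate buffer, measured as kinetic solubility, at pH 7.4 (a higher number here means a more soluble compound, a lower number a less soluble compound), compound 3 `Cc1oc(-c2c(Br)cccc2Br)nc1CN1CCC(C(=O)NCCCN2C[C@H](C)C[C@H](C)C2)CC1` gives 62.4 ug/mL. Compound 1 `Cc1ccc(C)c(-c2nc(CN3CCC(C(=O)NCCCN4C[C@H](C)C[C@H](C)C4)CC3)c(C)o2)c1` gives 56.1 ug/mL, and the two sit level, with a 1.1-fold higher number from compound 1 to compound 3 (0.05 log units; within the scatter). Compound 2 `Cc1oc(-c2ccccc2Cl)nc1CN1CCC(C(=O)NCCCN2C[C@H](C)C[C@H](C)C2)CC1` gives > 72 ug/mL, which is a limit of the assay and not a number. Compound 4 `Cc1oc(-c2c(Cl)cccc2Br)nc1CN1CCC(C(=O)NCCCN2C[C@H](C)C[C@H](C)C2)CC1` differs from compound 3 by a single swap, chloro in place of bromo on an aromatic carbon. The closest measured change is 2,6-dibromophenyl in place of 2-chlorophenyl, with an at least 1.1-fold lower number from compound 2 to compound 3 (0.06 log units; that floor lies within the scatter). The other change on this group, an at least 1.2-fold higher number from compound 1 to compound 2 (0.10 log units; that floor lies within the scatter), is also small. No step beyond the scatter is therefore expected in this assay, and the estimate is a 1.0-fold higher number from compound 3 to compound 4 (0.00 log units; within the scatter). Compound 4 is expected at 63 ug/mL, within a range of 43 ug/mL to 78 ug/mL.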

Compound 4, solubility: > 83 ug/mL
Compound 4 gave a limit, no number (the forecaster's own chance of this, stated with the estimate: 30%); at least 1.3-fold (0.11 log units) between middle value and limit.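

In this assay, going from 2,6-dibromophenyl to 2-bromo-6-chlorophenyl gives an at least 1.3-fold higher number from compound 3 to compound 4 (0.12 log units; that floor lies within the scatter), so chloro at this position costs nothing measurable, yet that floor cannot set the two compounds apart. Replacing 2,5-dimethylphenyl with the same 2-bromo-6-chlorophenyl group gives an at least 1.4-fold higher number from compound 1 to compound 4 (0.17 log units; that floor lies within the scatter), again only a floor. Compound 4 reads as a limit and not a number, and its step from compound 2 cannot be read: the limit of > 83 ug/mL in this assay, at which 1 of the 4 values shown sits.

Going by these compounds, how far compound 4 lies past its limit stays open. Also open, on these data alone, is whether an amine or a carboxylic acid at this position would give a step beyond the scatter.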